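Naphthalen-2-yl to 4-(trifluoromethyl)phenyl swap on two cores

The source may hold more compounds than are shown below. What is called first, only, known or untested is meant among the compounds shown, and "the series" means these compounds.

Measured so far in a functional assay on HL-60 cells (Homo sapiens) for inhibition, read by trypan blue exclusion, with a stated time of 72 h; a higher number here means a weaker inhibitor of growth, a lower number a stronger inhibitor of growth:
compound 1, `C=C(CC)C(=O)c1ccc(OCc2nc(-c3ccc4ccccc4c3)cs2)c(C)c1C`: 2000 nM
compound 2, `C=C(CC)C(=O)c1ccc(OCc2nc(-c3ccc(C(F)(F)F)cc3)cs2)c(C)c1C`: 1500 nM
compound 3, `C=C(CC)C(=O)c1ccc(OCc2nc(-c3ccc4ccccc4c3)cs2)c(Cl)c1Cl`: 3600 nM

Compound 1 and compound 2 share one core and differ in one place: 4-(trifluoromethyl)phenyl in place of naphthalen-2-yl on an aromatic carbon. The step is a 1.3-fold lower number from compound 1 to compound 2 (0.12 log units; within the scatter). Compound 3 carries a second core; how it differs from the core of compound 1 is not broken down here. In this assay compound 3 sits at the highest of the three numbers, within the scatter of compound 1 and beyond it only against compound 2.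

Compound 4, `C=C(CC)C(=O)c1ccc(OCc2nc(-c3ccc(C(F)(F)F)cc3)cs2)c(Cl)c1Cl`, has not yet been measured. It differs from compound 3 by 4-(trifluoromethyl)phenyl in place of naphthalen-2-yl on an aromatic carbon. For the measured compounds named here, this is the same change as the one from compound 1 to compound 2, made at the same place on the core of compound 3.

Going by the values given here, on that basis the step from compound 3 to compound 4 is expected to be small, about a 1.3-fold lower number from compound 3 to compound 4 (0.11 log units; within the scatter), resting on the single earlier instance of the same change, a 1.3-fold lower number from compound 1 to compound 2 (0.12 log units; within the scatter), which stayed within the scatter. Among the compounds with values here, since only one prior instance exists and it lies on a different core, the range is kept wide. Compound 4 is therefore estimated at 2800 nM in this assay, between 1200 nM and 6500 nM.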

Compound 4, concentration for 50% growth inhibition: 1600 nM
For compound 4 the middle estimate is 1.8-fold (0.24 log units) above the measured one; measured number inside the range.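

On the core of compound 3, 4-(trifluoromethyl)phenyl in place of naphthalen-2-yl gives a modest step in this assay, a 2.3-fold lower number from compound 3 to compound 4 (0.35 log units; beyond the scatter). Set beside the earlier instance, the step does not show the change behaving differently on the two cores: the same change on two cores in this assay, a 1.3-fold lower number (0.12 log units; within the scatter) from compound 1 to compound 2 and a 2.3-fold lower number (0.35 log units; beyond the scatter) from compound 3 to compound 4, 1.7-fold (0.23 log units) apart, within the scatter of two such steps. For the compounds shown here, the change therefore carries across these two cores with no difference that can be told apart from scatter, but this rests on one pair per core, only the step on the core of compound 3 lies beyond the scatter, and nothing here shows that the same would hold on a third core or explains why the two steps print at different sizes.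

The compounds shown place only naphthalen-2-yl and 4-(trifluoromethyl)phenyl on this aromatic carbon of the five-membered ring, so it stays open how a phenyl carrying a nitrile, an amine or a carboxylic acid would read in this assay. Also open, from the compounds shown here alone, is how the series responds to a longer chain in place of the ethyl group on the side of the carbonyl, which is the same in all four compounds.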